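Inverting One Stereocentre on an Already Inactive Thioglycoside

The compounds below may be only part of what the source reports. "The series", "measured", "known", "first", "only" and "open" are said of these compounds alone.

Compound 1 `NC(=S)/N=C1/CC[C@H]2CO[C@@H]1O2` opens the set. In a functional assay on LoVo cells (Homo sapiens) for cytotoxicity, read by CCK-8 assay, with a stated time of 72 h (a lower number here means a stronger inhibitor, a higher number a weaker inhibitor), compound 1 gives > 1000000 nM, which is a limit of the assay rather than a number (the limit of > 1000000 nM in this assay, at which 1 of the 3 values shown sits). Compound 2 `CC(=O)O[C@@H]1[C@@H](OC(C)=O)[C@H](S[C@@H]2C/C(=N/C(N)=S)[C@@H]3OC[C@H]2O3)OC[C@@H]1OC(C)=O` gives 1000000 nM in this assay, and compound 3 `CC(=O)OC[C@H]1O[C@@H](S[C@@H]2C/C(=N/C(N)=S)[C@@H]3OC[C@H]2O3)[C@H](OC(C)=O)[C@@H](OC(C)=O)[C@H]1OC(C)=O`, carrying an acetoxymethyl in place of hydrogen on a saturated ring carbon, gives 1000000 nM; the step of no change at the digits printed from compound 2 to compound 3 (within the scatter) lies within the scatter. Compound 3 thus stands level with compound 2 at the digits shown. Compound 4 `CC(=O)OC[C@H]1O[C@@H](S[C@@H]2C/C(=N/C(N)=S)[C@@H]3OC[C@H]2O3)[C@H](OC(C)=O)[C@@H](OC(C)=O)[C@@H]1OC(C)=O` differs from compound 3 only in that (the two compounds have the same atoms and bonds and differ only in configuration as drawn: 1 of 9 stereo elements differ; a stereocentre at a saturated ring carbon is drawn S in compound 3 and R in compound 4). Among the measured compounds shown here, no measured step involves such an inversion, and the sole measured step no change at the digits printed from compound 2 to compound 3 (within the scatter) showed nothing beyond the scatter, so no shift is expected. Compound 4 is therefore expected to give 1000000 nM, within 400000 nM to 2500000 nM, an estimated step of no change at the digits printed from compound 3 to compound 4 (within the scatter).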

Compound 4, half-maximal inhibitory concentration: 865000 nM
For compound 4 the middle estimate is 1.2-fold (0.06 log units) above the measured one; the measured number falls inside the stated range.
By their numbers in this assay, from the lowest: compounds 4, 2 and 3 (each within the scatter of the next).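

Among the compounds shown here, this is the first measured inversion in the set, and in this assay it gives a 1.2-fold lower number from compound 3 to compound 4 (0.06 log units; within the scatter), so changing this saturated ring carbon from S to R leaves the number within the scatter. The comparison isolates stereochemistry at this one position: the fact that compounds 3 and 4 differ only in the configuration as drawn. As far as these compounds go, whether the same inversion would matter in a compound with a much lower number stays open. So does the effect of a free hydroxyl or an amine in place of the acetoxy groups.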